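Removing the fluoro group from compound 2

The compounds below may be only part of what the source reports. "The series", "measured", "known", "first", "only" and "open" are said of these compounds alone.

In a functional assay on A549 cells (Homo sapiens) for cytotoxicity, read by MTT assay, with a stated time of 68 h (a higher number here means a weaker inhibitor, a lower number a stronger inhibitor), compound 2 `O=C(Nc1cccc(-c2ccc(F)cc2)c1)C(Cl)Cl` gives 7840 nM and compound 1 `O=C(Nc1cccc(-c2ccccc2F)c1)C(Cl)Cl` gives 13200 nM as two values within the scatter of each other. The change hydrogen in place of fluoro on an aromatic carbon leads to compound 3 `O=C(Nc1cccc(-c2ccccc2)c1)C(Cl)Cl` with hydrogen in place of fluoro on an aromatic carbon, para to a large group. No measured pair shows this change alone, and the two close values give no reason to expect a shift beyond the scatter in this assay for it. The estimated step of a 1.2-fold higher number from compound 2 to compound 3 (0.08 log units; within the scatter) is expected to stay within the scatter. For compound 3 the estimate is 9500 nM as the expected value, with 4500 nM to 20000 nM as the expected range.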

Compound 3, half-maximal inhibitory concentration: 8900 nM
Beside the measured number, compound 3's estimate is 1.1-fold (0.03 log units) above it; the range from low to high includes it.
By their numbers in this assay, from the lowest: compounds 2, 3 and 1 (each within the scatter of the next).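

Hydrogen in place of fluoro, para to a large group, now has a direct reading in this assay with a 1.1-fold higher number from compound 2 to compound 3 (0.06 log units; within the scatter) and stays within the scatter. The same exchange from the other fluoro compound gives a 1.5-fold lower number from compound 1 to compound 3 (0.17 log units; within the scatter) and is also within the scatter, so neither fluoro compound is separated from the unsubstituted compound 3 here. Nothing available explains these close values.

From the compounds shown here alone, whether an amine or a carboxylic acid at this place would give a step beyond the scatter remains open. Changes elsewhere on the shared core also remain open.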